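This account rests on a few compounds, and the source may have more. Where it says the series, first, only, none or still open, it means among the compounds named here.

Compound 1 `Cc1ccc(-c2nn(-c3ccc(F)cc3F)cc2CNCCN2CCN(C)CC2)cc1` belongs to a small set tested in an ADME assay on Huh-7 cells (Homo sapiens) for cytotoxicity; a higher number here means that more compound is tolerated, a lower number that less compound is tolerated. Its reading there is a limit of the measurement rather than a number: compound 1 shows > 20000 nM. Compound 2 `Cc1ccccc1-c1nn(-c2ccc(F)cc2F)cc1CNCCCN1CCN(C)CC1` likewise reaches only a limit, with > 20000 nM in this assay. Compound 3 `Cc1ccccc1-c1nn(-c2ccc([N+](=O)[O-])cc2)cc1CNCCN1CCN(C)CC1` also ends at a limit, giving > 20000 nM in this assay. On the numbers shown, compound 1 therefore stands where every compound in the set stands, since (the limit of > 20000 nM in this assay, at which 3 of the 3 values shown sit). Compound 4 `CN1CCN(CCNCc2cn(-c3ccc(F)cc3F)nc2C(C)(C)C)CC1` has not yet been measured in this assay. It differs from compound 1 in one place: tert-butyl in place of 4-methylphenyl on an aromatic carbon. Within the data shown here, no step between measured compounds is available, so the expected step from compound 1 to compound 4 is none beyond the scatter, a step that the limit leaves unreadable from compound 1 to compound 4. Compound 4 is thus estimated at 30000 nM in this assay, within 15000 nM to 80000 nM.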

Compound 4, half-maximal cytotoxic concentration: > 20000 nM
Compound 4 ended at the assay's limit; the forecaster's own chance of this, stated with the estimate: 75%; the middle value lies beyond the limit too.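

Compound 1 and compound 4 both end at a limit of the measurement, so no step between them can be read: the limit of > 20000 nM in this assay, at which 4 of the 4 values shown sit.

The compounds shown leave open what separates tert-butyl from 4-methylphenyl in this assay, and at what concentration any of them stops being tolerated.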